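A few compounds are considered here, and "the series" means these few. Any claim that something is new, unique, unknown or untested is made for them only; others in the source may bear on it.

Measured compounds:
compound 1, `CCCc1c(COc2ccc(C(=O)C(C)(C)Cc3nnn[nH]3)cc2)ccc(C(C)=O)c1O`, 10.8 mg/kg
compound 2, `CCCc1c(COc2ccc(C(=O)CC(C)(C)Cc3nnn[nH]3)cc2)ccc(C(C)=O)c1O`, 1.3 mg/kg

In an in vivo functional assay on the whole organism (Rattus norvegicus) with cysteinyl leukotriene receptor (Homo sapiens) as the target (a lower number here means that less compound is needed, a higher number that more compound is needed for the effect), compound 2 gives the lowest of the two numbers; its nearest neighbour is compound 1, whose value in this assay is 10.8 mg/kg. Within the data shown here, the only measured step is an 8.3-fold lower number from compound 1 to compound 2 (0.92 log units; beyond the scatter), which lengthens the chain between the carbonyl and the tetrazole.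

Compound 3, `CCCc1c(COc2ccc(C(=O)CCCCCCc3nnn[nH]3)cc2)ccc(C(C)=O)c1O`, has not yet been measured. It differs from compound 2 by 5-(1H-tetrazol-5-yl)pentyl in place of 1-((1H-tetrazol-5-yl)methyl)-1-methylethyl on a saturated chain carbon bound to a carbonyl carbon. Among the measured compounds shown here, the chain is lengthened again and the two methyl groups are gone, so the step from compound 1 to compound 2 bears on it only in part; no measured step covers the loss of the methyl groups. A further lowering would be consistent with that step, but the change is larger than any measured one, so compound 3 is expected to give about 1.5 mg/kg, between 0.4 mg/kg and 6 mg/kg, a step of a 1.2-fold higher number from compound 2 to compound 3 (0.06 log units; within the scatter) that is estimated to stay within the scatter.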

Compound 3, dose for half-maximal effect: 8.5 mg/kg
Beside the measured number, compound 3's estimate is 5.7-fold (0.75 log units) below it; measured number outside the range, above it.
By their numbers in this assay, from the lowest: compound 2; then compounds 3 and 1 (each within the scatter of the next).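

At this position, on a saturated chain carbon bound to a carbonyl carbon, 5-(1H-tetrazol-5-yl)pentyl in place of 1-((1H-tetrazol-5-yl)methyl)-1-methylethyl gives a 6.5-fold higher number from compound 2 to compound 3 (0.82 log units; beyond the scatter) in this assay, so the lowering seen on the first lengthening does not continue to this unbranched chain. With 6-(1H-tetrazol-5-yl)hexyl on the carbonyl carbon, the result is a 1.3-fold lower number from compound 1 to compound 3 (0.10 log units; within the scatter), which leaves the low number with compound 2 alone among these three. Nothing available explains this reversal.

On these data alone, the chain length and the two methyl groups change together in compound 3, so their separate shares remain unknown, and an unbranched chain of the length found in compound 2 would be the direct comparison. As far as these compounds go, whether a carboxylic acid in place of the tetrazole would hold the number of compound 2 also stays open.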